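The source may hold more compounds than are shown below. What is called first, only, known or untested is meant among the compounds shown, and "the series" means these compounds.

Measured so far:

Compound 1 `CC(C)(O/N=C(\C(=O)N[C@@H]1C(=O)N(S(=O)(=O)O)[C@@H]1CN1CCNC1=O)c1csc(N)n1)C(=O)O`: in a physicochemical assay for metabolic stability, read by HPLC and mass spectrometry, in phosphate buffer, at 37 degrees C, at pH 7.4 (on this read-out higher numbers stand for a longer-lived compound and lower numbers for a shorter-lived compound), compound 1 gives > 1000 h, which is a limit of the assay and not a number.
Compound 2 `CC(C)(O/N=C(\C(=O)N[C@@H]1C(=O)N(S(=O)(=O)O)[C@@H]1Cn1cc(NC(=O)C[N+](C)(C)C)nn1)c1csc(N)n1)C(=O)O`: in this assay compound 2 gives > 37 h, again a limit and not a number.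

Compound 1 therefore stands at a limit rather than at a measured number, as shown by the limit of > 1000 h in this assay, at which 1 of the 2 values shown sits. The only other value, for compound 2, is a limit as well, as shown by the limit of > 37 h in this assay, at which 1 of the 2 values shown sits. Between these two limits nothing can be ordered, and no step between measured compounds that differ in one place is available.

Compound 3 `CC(C)(O/N=C(\C(=O)N[C@@H]1C(=O)N(S(=O)(=O)O)[C@@H]1Cn1ncnc1CN)c1csc(N)n1)C(=O)O` differs from compound 1 in one place: a group of 7 heavy atoms (3 carbon, 4 nitrogen; one five-membered aromatic ring with 3 hetero atoms) in place of a group of 6 heavy atoms (3 carbon, 2 nitrogen, 1 oxygen; one five-membered non-aromatic ring with 2 hetero atoms), on a saturated chain carbon bound to a saturated ring carbon. No measured step informs this change, so the expectation rests only on the two limits shown. The step from compound 1 to compound 3 is estimated to be an at least 1.6-fold lower number from compound 1 to compound 3 (0.22 log units; that floor lies within the scatter), that is, no change beyond the usual scatter in this assay, with some chance that only a limit is reported again. Compound 3 is expected to give 600 h, with a range from 100 h to 2000 h.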

Compound 3, half-life: > 37 h
Compound 3 gave a limit, no number; the forecaster's own chance of this, stated with the estimate: 60%; the middle value lies beyond the limit too.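

Compound 1 and compound 3 both end at limits of this assay and not at numbers, so the step from compound 1 to compound 3 cannot be read. The compounds shown leave open how long any of them actually lasts in this assay, and whether replacing the 2-oxoimidazolidin-1-yl group changes that at all.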